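Acetamido to benzamido: an untested change

The source may report more compounds than this note shows. Statements on the series, on what has been measured and on what is new or still open speak of the compounds shown alone.

Compound 2 `CC(=O)Nc1cc(NC(=O)Nc2cccc(Oc3ccccc3)c2)ccc1C` was tested in a functional assay on A375P cells (Homo sapiens) for antiproliferative activity; on this read-out higher numbers stand for weaker inhibition and lower numbers for stronger inhibition. In this assay compound 2 reaches only the limit of > 30000 nM, which is not a measured number. Compound 1 `CC(=O)Nc1cc(NC(=O)Nc2cccc(C(C)=O)c2)ccc1C` gives 22100 nM in this assay. The step of an at least 1.3-fold higher number from compound 1 to compound 2 (0.13 log units; that floor lies within the scatter) swaps phenoxy for acetyl on an aromatic carbon, and only a floor for it is known because of the limit of > 30000 nM in this assay, at which 1 of the 2 values shown sits. Compound 3 `Cc1ccc(NC(=O)Nc2cccc(Oc3ccccc3)c2)cc1NC(=O)c1ccccc1` differs from compound 2 in another place: phenyl in place of methyl on a carbonyl carbon, so that acetamido becomes benzamido. Among the measured compounds shown here, no measured step touches this carbonyl carbon, so none of the measured steps bears directly on the change. Compound 3 is therefore expected to stay close to where compound 2 stands, with an expected step of a number no higher from compound 2 to compound 3 (the limit leaves the size open). For compound 3 the estimated value in this assay is 30000 nM, ranging from 8000 nM to 100000 nM, and it will most likely again be reported only as a limit.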

Compound 3, half-maximal inhibitory concentration: > 30000 nM
Compound 3: no number, only a limit; the forecaster's own chance of this, stated with the estimate: 70%; the middle value lies on the limit itself.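

Compound 2 and compound 3 both give only a limit in this assay, not a number, so no step can be read between them: the limit of > 30000 nM in this assay, at which 2 of the 3 values shown sit.

The compounds shown leave open whether benzamido in place of acetamido changes the activity at all, and what the true values of compound 2 and compound 3 are.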